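From the assay limit back towards activity?

This account rests on a few compounds, and the source may have more. Where it says the series, first, only, none or still open, it means among the compounds named here.

In a functional assay on A-375 cells (Homo sapiens) for antiproliferative activity, read by MTT assay, with a stated time of 24 h (on this read-out higher numbers stand for weaker inhibition and lower numbers for stronger inhibition), compound 1 (`COc1cc(OC)c(-c2coc3cc(OCc4ccccc4)ccc3c2=O)cc1OC`) gives 1640 nM as its value. Compound 2 (`COc1cccc(C(=O)Oc2ccc3c(=O)c(-c4cc(OC)c(OC)cc4OC)coc3c2)c1`) gives only a limit, > 10000 nM and no exact number. Compound 3 (`COc1cc(OC)c(-c2coc3cc(OCC(=O)c4cccc(C(F)(F)F)c4)ccc3c2=O)cc1OC`) also gives only a limit, > 10000 nM and no exact number, so it sits at the limit of > 10000 nM in this assay, at which 2 of the 3 values shown sit, and cannot be ranked further. Compound 4 (`COc1cc(OC)c(-c2coc3cc(OCc4ccccc4C)ccc3c2=O)cc1OC`) differs from compound 3 in one place (2-methylphenyl in place of (3-(trifluoromethyl)phenyl)carbonyl on a saturated chain carbon bound to an oxygen on an aromatic ring). Within the data shown here, two steps bear on this: an at least 6.0-fold higher number from compound 1 to compound 2 (0.78 log units; beyond the scatter) and an at least 6.0-fold higher number from compound 1 to compound 3 (0.78 log units; beyond the scatter) (each beyond the scatter). Like the phenyl of compound 1 with 1640 nM on the same saturated chain carbon, the 2-methylphenyl carries no carbonyl. So an at least 5.0-fold lower number from compound 3 to compound 4 (0.69 log units; beyond the scatter) is expected in this assay as a move towards stronger inhibition. Compound 4 is estimated at 2000 nM (expected range 600 nM to 7000 nM).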

Compound 4, half-maximal inhibitory concentration: 1360 nM
Beside the measured number, compound 4's estimate is 1.5-fold (0.17 log units) above it; the range from low to high includes it.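

In this assay, a benzyl type of group without a carbonyl again gives a measured value: 2-methylphenyl on the saturated chain carbon gives an at least 7.3-fold lower number from compound 3 to compound 4 (0.86 log units; beyond the scatter), and 2-methylbenzyl on the oxygen gives an at least 7.3-fold lower number from compound 2 to compound 4 (0.86 log units; beyond the scatter). The added methyl on the aromatic ring leaves the value unchanged within the usual scatter, with a 1.2-fold lower number from compound 1 to compound 4 (0.08 log units; within the scatter). Compound 2 and compound 3 each give a limit, not a number: the limit of > 10000 nM in this assay, at which 2 of the 4 values shown sit.

As far as these compounds go, how far those two compounds lie past the limit stays open. So does whether an amine or a carboxylic acid in place of the methyl would shift the value.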